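Swapping the Amide Aryl Group in a Kinase Inhibitor Series

The source may report more compounds than this note shows. Statements on the series, on what has been measured and on what is new or still open speak of the compounds shown alone.

Of the compounds shown here, three have been measured in an assay on isolated protein for inhibition of Rho-associated protein kinase 1 (Homo sapiens), read by scintillation counting, radiometric assay and 33P incorporation, with a stated time of 40 min, in the presence of a further agent that is not named here; on this read-out lower numbers stand for stronger inhibition and higher numbers for weaker inhibition. Compound 1, with structure `CN(C)c1ccc(C(=O)Nc2cccc(NC(=O)COc3ccc4c(c3)CCC(=O)N4)c2)cc1`, reaches only the limit of this assay, reported as > 10000 nM. Compound 2, with structure `CC(=O)c1ccc(OCC(=O)Nc2cccc(NC(=O)c3ccc(N(C)C)cc3)c2)cc1F`, gives 445 nM in this assay. Compound 3, with structure `CCc1ccc(C(=O)Nc2cccc(NC(=O)COc3ccc4c(=O)ccoc4c3)c2)cc1`, gives 235 nM; this is the lowest of the two numbers shown, but it lies within the usual scatter of compound 2, so the two cannot be placed in order.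

Going by the values given here, the one step between measured compounds that differ in a single place, an at least 22-fold lower number from compound 1 to compound 2 (1.35 log units; beyond the scatter), changes the group on the oxygen on a saturated carbon, a different place from the one altered below.

Compound 4, with structure `CC(C)(C)c1cc(C(=O)Nc2cccc(NC(=O)COc3ccc4c(=O)ccoc4c3)c2)no1`, differs from compound 3 by 5-(tert-butyl)-1,2-oxazol-3-yl in place of 4-ethylphenyl on a carbonyl carbon. No measured step touches this carbonyl carbon, so the numbers shown give no guide to the size or direction of the change; the shared core is kept, which is the only anchor. Compound 4 is therefore expected to give roughly 300 nM in this assay, with a wide range from 60 nM to 1500 nM. That estimate means an expected step of a 1.3-fold higher number from compound 3 to compound 4 (0.11 log units; within the scatter), held loosely.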

Compound 4, half-maximal inhibitory concentration: 101 nM
Estimate against measurement, compound 4: 3.0-fold (0.47 log units) above; measured number inside the range.
By their numbers in this assay, from the lowest: compound 4; then compounds 3 and 2 (each within the scatter of the next). At a limit, above all of these: compound 1.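

In this assay, going by these compounds alone, this is the first measured change on the carbonyl carbon whose other neighbour is the amide-type nitrogen, and it shows that the group here can move the number: with the shared core kept, 5-(tert-butyl)-1,2-oxazol-3-yl in place of 4-ethylphenyl gives a 2.3-fold lower number from compound 3 to compound 4 (0.37 log units; beyond the scatter). The step is modest, but it shows that, in this pair, a six-membered aromatic ring of carbon only is not required on this carbonyl carbon, since a five-membered aromatic ring takes its place without any loss. The swap changes several things at once: the ring size, the ring atoms, the alkyl group and the count of hydrogen-bond acceptors, which goes from 0 to 2.

The compounds shown leave open which of these changes matters, and how the result would carry over to other cores; a 4-tert-butylphenyl group or a 5-methyl-1,2-oxazol-3-yl group on the same carbonyl carbon would begin to separate the ring from the tert-butyl group. Nothing measured here gives a reason for the step.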